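The compounds below may be only part of what the source reports. "The series", "measured", "known", "first", "only" and "open" are said of these compounds alone.

Working notes, urea series. Compound 1 `Cc1cc(C)c(NC(=O)N(Cc2ccc(-c3n[nH]c(C)n3)cc2)C2CCCCCC2)c(C)c1` gives 120 nM in an assay on microsomes from intestine for inhibition of acyl-CoA:cholesterol acyltransferase (Oryctolagus cuniculus); on this read-out lower numbers stand for stronger inhibition and higher numbers for weaker inhibition. Compound 2 `Cc1cc(C)c(NC(=O)N(Cc2ccc(-c3ccnn3C)cc2)C2CCCCCC2)c(C)c1` gives 24 nM; the step of a 5.0-fold lower number from compound 1 to compound 2 (0.70 log units; beyond the scatter) is the only one measured, and compound 2 holds the lower of the two numbers seen so far, beyond the scatter from compound 1.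

Compound 3 `Cc1cc(C)c(NC(=O)N(Cc2ccc(-n3ccnn3)cc2)C2CCCCCC2)c(C)c1` is not yet measured. Relative to compound 2 the change is 1H-1,2,3-triazol-1-yl in place of 1-methyl-1H-pyrazol-5-yl on an aromatic carbon, on the aromatic carbon para to the large group. Going by the values given here, no measured step covers this exact exchange; the nearest comparison is the azole swap between compound 1 and compound 2, which moved the read-out by a modest amount. Among the compounds with values here, since the group entering in compound 3 also differs from the one in compound 2 in ring heteroatom count and lacks the methyl, a moderate shift toward the weaker side is expected, but without direct precedent the estimate is kept wide. For compound 3 the expected value is 50 nM, range 15 nM to 170 nM, corresponding to an expected step of a 2.1-fold higher number from compound 2 to compound 3 (0.32 log units; beyond the scatter).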

Compound 3, half-maximal inhibitory concentration: 42 nM
Estimate against measurement, compound 3: 1.2-fold (0.08 log units) above, and the stated range covers the measured number.
By their numbers in this assay, from the lowest: compounds 2 and 3 (each within the scatter of the next); then compound 1.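

In this assay the step of a 1.8-fold higher number from compound 2 to compound 3 (0.24 log units; within the scatter) shows that, on the aromatic carbon para to a large group, 1H-1,2,3-triazol-1-yl can stand in place of 1-methyl-1H-pyrazol-5-yl without a separation beyond the scatter. The step of a 2.9-fold lower number from compound 1 to compound 3 (0.46 log units; beyond the scatter) then shows that the gap to compound 1 is not tied to 1-methyl-1H-pyrazol-5-yl alone, as a second azole also gives a lower number than 5-methyl-1H-1,2,4-triazol-3-yl. Nothing available explains either step.

The compounds shown leave open whether a non-azole group at this position, such as a carboxylic acid, a primary amine or a morpholine ring, would keep the read-out in this range. Also open, going by these compounds, is whether the azole ranking would hold with a change elsewhere on the shared core.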